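The compounds below may be only part of what the source reports. "The series", "measured", "known", "first", "only" and "open" are said of these compounds alone.

Measured compounds:
Compound 1 `C[C@@H]1CN(c2sc(C(F)(F)F)nc2-c2nc3ccccc3[nH]2)CCN1C(=O)Cn1ccc(C(=O)O)n1` gives 5570 nM in a functional assay on Venous blood for antagonist activity at C-X-C chemokine receptor type 3 (Homo sapiens), read by flow cytometry, with a stated time of 30 min, in the presence of a further agent that is not named here; a higher number here means a weaker inhibitor, a lower number a stronger inhibitor.
Compound 2 `Cc1nc(C)n(CC(=O)N2CCN(c3sc(C(F)(F)F)nc3-c3nc4ccc(C5CCOCC5)cc4[nH]3)C[C@H]2C)n1` gives 123 nM in this assay.

Compound 1 has the higher of the two numbers in this assay, its nearest neighbour being compound 2, whose number is lower by a margin that lies beyond the scatter. Going by the values given here, compound 2, however, differs from compound 1 in more than one place, so no single step between them can be isolated.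

Compound 3 `C[C@@H]1CN(c2sc(C(F)(F)F)nc2-c2nc3ccccc3[nH]2)CCN1C(=O)Cn1cc(Cl)cn1` is not yet measured. It is obtained from compound 1 by the change 4-chloro-1H-pyrazol-1-yl in place of 3-carboxy-1H-pyrazol-1-yl on a saturated chain carbon bound to a carbonyl carbon: the shared core is untouched, the hydrogen-bond donor of the carboxy group is lost, and a chlorine enters on the pyrazole. Among the compounds with values here, no measured pair isolates this change, so the expected size of the step rests on the observation that the only compound here with a neutral azole attached to the carbonyl-bound chain carbon, compound 2, gives the lower number. Compound 3 is therefore expected to give a lower number than compound 1, with a step of a 3.7-fold lower number from compound 1 to compound 3 (0.57 log units; beyond the scatter) estimated for the move from compound 1 to compound 3, although the two other differences in compound 2 mean this expectation is uncertain.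

Compound 3 is estimated at 1500 nM in this assay, with a range from 300 nM to 6000 nM.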

Compound 3, half-maximal inhibitory concentration: 251 nM
For compound 3 the middle estimate is 6.0-fold (0.78 log units) above the measured one, outside the stated range (below it).
By their numbers in this assay, from the lowest: compound 2; then compound 3; then compound 1.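

Setting 4-chloro-1H-pyrazol-1-yl in place of 3-carboxy-1H-pyrazol-1-yl on a saturated chain carbon bound to a carbonyl carbon gives in this assay a 22-fold lower number from compound 1 to compound 3 (1.35 log units; beyond the scatter) and is the first change at this position that can be read on its own, with the shared core untouched. It shows that the number at this position depends strongly on the group the chain carries, and that the hydrogen-bond donor of the carboxy group is not required for a lower number, since compound 3 has no hydrogen-bond donor in this group and gives 251 nM in this assay. No evidence is available here that accounts for the size of this step.

The step removes the carboxy group and brings in a chlorine together, so the compounds shown cannot say how much of it belongs to each, and a plain 1H-pyrazol-1-yl group or a 4-carboxy-1H-pyrazol-1-yl group would separate the two. They also leave open how a nitrile or an amine on the pyrazole would read, and whether the step would keep its size on the core of compound 2.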